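Removing a methyl from an amide nitrogen: cytotoxicity in liver cells

The source may hold more compounds than are shown below. What is called first, only, known or untested is meant among the compounds shown, and "the series" means these compounds.

Three compounds have been measured:

Compound 1, `CS(=O)(=O)c1ccc(C(=O)NCC(=O)N(Cc2ccccc2)Cc2ccccc2)cc1[N+](=O)[O-]`: in an ADME assay on HepG2 cells (Homo sapiens) for cytotoxicity, read by CellTiter-Glo and ATP content, with a stated time of 72 h (a higher number here means that more compound is needed for the effect, a lower number that less compound is needed), compound 1 gives 11900 nM.
Compound 2, `CN(CC(=O)N(Cc1ccccc1)Cc1ccccc1)C(=O)c1ccc(S(C)(=O)=O)c([N+](=O)[O-])c1`: in this assay compound 2 reaches only a limit of the assay, > 27000 nM.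
Compound 3, `CN(CC(=O)N1CCc2ccccc2C1)C(=O)c1ccc(S(C)(=O)=O)c([N+](=O)[O-])c1`: in this assay compound 3 likewise reaches only a limit of the assay, > 27000 nM.

Compound 2 and compound 1 share a core and differ in a single place: hydrogen in place of methyl on an amide-type nitrogen. That change gives an at least 2.2-fold lower number from compound 2 to compound 1 (0.35 log units; beyond the scatter). Only a lower bound on the size of this step is known because of the limit of > 27000 nM in this assay, at which 2 of the 3 values shown sit.

Compound 4, `CS(=O)(=O)c1ccc(C(=O)NCC(=O)N2CCc3ccccc3C2)cc1[N+](=O)[O-]`, has not yet been measured in this assay. It stands to compound 3 as compound 1 stands to compound 2: the one difference is hydrogen in place of methyl on an amide-type nitrogen, so the methyl leaves and a hydrogen enters at a nitrogen whose surroundings are described in exactly the same words in both pairs, and the change is the same. Compound 3 and compound 4 sit on a different core from compound 2 and compound 1; the difference between the two cores is not broken down here.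

Since the change is the same and compound 3 starts from the same limit as compound 2, the step is expected to resemble an at least 2.2-fold lower number from compound 2 to compound 1 (0.35 log units; beyond the scatter), that is an expected at least 2.0-fold lower number from compound 3 to compound 4 (0.31 log units; beyond the scatter). For compound 4 the estimated value in this assay is 13000 nM, with an expected range from 5000 nM to 27000 nM.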

Compound 4, half-maximal effective concentration: > 27000 nM
Compound 4: a limit, no number (the forecaster's own chance of this, stated with the estimate: 35%); middle value at least 2.0-fold (0.31 log units) from the limit.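

In this assay compound 4 reaches only a limit, > 27000 nM. Compound 3 stands at that same limit, so no step from compound 3 to compound 4 can be read: the limit of > 27000 nM in this assay, at which 3 of the 4 values shown sit.

On these data alone, whether hydrogen in place of methyl on the amide-type nitrogen changes the number at all on the core of compound 3 stays open.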